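The compounds below may be only part of what the source reports. "The series", "measured", "known", "first", "only" and "open" are said of these compounds alone.

Measured so far:
compound 1, `Cc1cc(C)c(S(=O)(=O)N2CCC(N3CCC(O)CC3)CC2)c(C)c1` — 106 nM
compound 2, `CC1CCN(C2CCN(S(=O)(=O)c3ccc(OCc4ccccc4)cc3)CC2)CC1` — 385 nM

Two compounds have numbers in a functional assay on DLD-1 cells (Homo sapiens) for antiproliferative activity, read by CellTiter-Glo, with a stated time of 72 h; a higher number here means a weaker inhibitor, a lower number a stronger inhibitor. Compound 1 gives 106 nM and compound 2 gives 385 nM; compound 1 stands lowest of the two, and the gap to compound 2 is beyond the scatter. Among the compounds with values here, the two structures differ in more than one place, so no single step between them can be read off.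

Compound 3, `Cc1cc(C)c(S(=O)(=O)N2CCC(N3CCC(C)OC3)CC2)c(C)c1`, is the next member and has not yet been measured in this assay. It keeps the core of compound 1 and differs from it only at one saturated ring carbon: a group of 7 heavy atoms (5 carbon, 1 nitrogen, 1 oxygen; one six-membered non-aromatic ring with 2 hetero atoms) in place of a group of 7 heavy atoms (5 carbon, 1 nitrogen, 1 oxygen; one six-membered non-aromatic ring with 1 hetero atom), on a saturated ring carbon. The group that leaves carries one hydrogen-bond donor; the group that enters carries none, with the same count of heavy atoms and acceptors.

Within the data shown here, no measured pair shows this kind of change, so the size of the step is open. A modest rise in this assay is expected, around the edge of the scatter; the estimated step from compound 1 to compound 3 is a 1.9-fold higher number from compound 1 to compound 3 (0.28 log units; within the scatter). For compound 3 the expected value is 200 nM, with a range from 80 nM to 600 nM.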

Compound 3, half-maximal inhibitory concentration: 92 nM
Compound 3: middle estimate off by 2.2-fold (0.34 log units), on the high side; low and high end bracket the measured number.
By their numbers in this assay, from the lowest: compounds 3 and 1 (each within the scatter of the next); then compound 2.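

In this assay, the exchange of the 4-hydroxypiperidin-1-yl group of compound 1 for a six-membered non-aromatic ring with 2 hetero atoms, holding the same count of heavy atoms, comes with a 1.2-fold lower number from compound 1 to compound 3 (0.06 log units; within the scatter) and leaves the two compounds level. Within the data shown here, this is the first readable step, and it shows that, on this saturated ring carbon of the shared core, a group with no hydrogen-bond donor can stand in for one that carries a hydrogen-bond donor with no change beyond the scatter, at least for this one pair. No measured property of either group accompanies the step, so the data offer no explanation for this result.

Among these compounds, only this single pair speaks to the position, so it remains open whether the tolerance extends to a group of another kind on the same ring carbon, such as a primary amine, a carboxylic acid or a longer alkyl chain. Compound 2 differs from compound 1 and compound 3 in more than one place, so the contribution of its benzyloxy-bearing arene and its methyl-bearing ring to its higher number cannot be separated.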